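Carboxyphenyl for aminobutyl on the aromatic nitrogen

This account rests on a few compounds, and the source may have more. Where it says the series, first, only, none or still open, it means among the compounds named here.

Of the compounds shown here, two built on the shared core have been measured. Compound 1 `CNC(=O)[C@@]12C[C@@H]1[C@@H](n1cnc3c(NCc4cccc(Cl)c4)nc(C#CCCCCc4cn(-c5ccc(N)cc5)nn4)nc31)[C@H](O)[C@@H]2O` bears a 4-aminophenyl on an aromatic nitrogen, and in an assay on CHO cells for displacement of a labelled ligand from adenosine receptor A1 (Homo sapiens), read by scintillation counting, tested at 10 uM (on this read-out higher numbers stand for more inhibition at the one concentration tested (going by the name of the read-out) and lower numbers for less inhibition), compound 1 gives 3%. Compound 2 `CNC(=O)[C@@]12C[C@@H]1[C@@H](n1cnc3c(NCc4cccc(Cl)c4)nc(C#CCCCCc4cn(CCCCN)nn4)nc31)[C@H](O)[C@@H]2O` carries a 4-aminobutyl in that place; in this assay compound 2 gives 13%. The step between them, a number 10 percentage points higher from compound 1 to compound 2 (within the scatter), lies within the scatter, so the two numbers cannot be told apart, and compound 2 stands alongside compound 1 at the low end of the scale in this assay.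

The third compound, compound 3 `CNC(=O)[C@@]12C[C@@H]1[C@@H](n1cnc3c(NCc4cccc(Cl)c4)nc(C#CCCCCc4cn(-c5ccc(C(=O)O)cc5)nn4)nc31)[C@H](O)[C@@H]2O`, is not yet measured. Its change from compound 2 is 4-carboxyphenyl in place of 4-aminobutyl on an aromatic nitrogen. Among the compounds with values here, only one measured step touches this position, a number 10 percentage points higher from compound 1 to compound 2 (within the scatter), and it stayed within the scatter even though 4-aminobutyl took the place of 4-aminophenyl. Nothing on record therefore points to a step beyond the scatter for the new 4-carboxyphenyl, and the expected step is a number 7 percentage points lower from compound 2 to compound 3 (within the scatter). Compound 3 is estimated to give 6% in this assay, with an expected range from -8% to 22%.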

Compound 3, a percentage reported as inhibition, at one concentration (the size of the read-out at that concentration, not a potency): 0%
Beside the measured number, compound 3's estimate is 6 percentage points above it; the measured number falls inside the stated range.
By their numbers in this assay, from the lowest: compounds 3, 1 and 2 (each within the scatter of the next, the first and the last beyond it).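

In this assay, within the data shown here, 4-carboxyphenyl in place of 4-aminobutyl on the aromatic nitrogen gives the first step at this position that lies beyond the scatter, a number 13 percentage points lower from compound 2 to compound 3 (beyond the scatter), though it remains modest and stays at the low end of the scale. With the six-membered aromatic ring kept, carboxy in place of amino on an aromatic carbon gives a number 3 percentage points lower from compound 1 to compound 3 (within the scatter), so exchanging these two groups on the ring produces no change that can be read, and compound 2 stands apart from compound 3 only, not from compound 1. No data are available to explain these numbers.

The step between compound 2 and compound 3 changes both the chain and its end group, leaving open which of the two carries the difference; a butyl chain ending in a carboxylic acid or an unsubstituted phenyl on the same aromatic nitrogen would separate them. From the compounds shown here alone, it also remains open whether any other group at this position, such as a longer chain ending in an amine, would move the number clear of the low end of the scale.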